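A few compounds are considered here, and "the series" means these few. Any claim that something is new, unique, unknown or untested is made for them only; others in the source may bear on it.

For the measured compounds named here, compound 2 `Cn1c(C2CC2)nc2ccc(-n3ccc(OCc4ncc(Cl)cn4)cc3=O)cc21` stands highest of the two numbers so far: in an assay on CHO cells for displacement of a labelled ligand from melanin-concentrating hormone receptor 1 (Rattus norvegicus), read by scintillation counting, with a stated time of 1 h (on this read-out higher numbers stand for weaker inhibition and lower numbers for stronger inhibition), compound 2 gives 900 nM, while compound 1 `Cn1c(C2CC2)nc2ccc(-n3ccc(OCc4ccc(F)cc4)cc3=O)cc21` gives 28 nM. Going by the values given here, the only measured step, a 32-fold higher number from compound 1 to compound 2 (1.51 log units; beyond the scatter), went the other way. Among the compounds with values here, compound 3 `Cn1c(C2CC2)nc2ccc(-n3ccc(OCc4csc(Cl)c4)cc3=O)cc21` carries 5-chlorothiophen-3-yl in place of 5-chloropyrimidin-2-yl on a saturated chain carbon bound to an oxygen on an aromatic ring, so no measured step covers this change directly; the enters group, with one hetero atom in a five-membered ring, sits between the groups of compound 1 and compound 2. A lower number than compound 2 is expected, smaller than that step. The expected step is a 6.0-fold lower number from compound 2 to compound 3 (0.78 log units; beyond the scatter). Compound 3 is estimated at 150 nM, range 40 nM to 600 nM.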

Compound 3, half-maximal inhibitory concentration: 9.3 nM
Beside the measured number, compound 3's estimate is 16-fold (1.21 log units) above it, and the stated range ends above it.
By their numbers in this assay, from the lowest: compound 3; then compound 1; then compound 2.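

A heteroaromatic ring on a saturated chain carbon bound to an oxygen on an aromatic ring is not in itself a loss: 5-chlorothiophen-3-yl in place of 5-chloropyrimidin-2-yl gives a 97-fold lower number from compound 2 to compound 3 (1.99 log units; beyond the scatter) and recovers more than the pyrimidine lost. It also surpasses 4-fluorophenyl, with a 3.0-fold lower number from compound 1 to compound 3 (0.48 log units; beyond the scatter) and compound 3 the lowest number of the three. Nothing available bears on why the two chlorinated rings differ so widely.

Open: whether the chlorine is needed, and how an unsubstituted thiophen-3-yl or a 5-methylthiophen-3-yl would read here.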